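This account rests on a few compounds, and the source may have more. Where it says the series, first, only, none or still open, it means among the compounds named here.

Series measured in a functional assay on Huh-5-2 cells (Homo sapiens) for cytotoxicity, read by microscopy; a higher number here means that more compound is tolerated, a lower number that less compound is tolerated:

Compound 1 `CC(=O)OC[C@H]1O[C@@H](n2c(=S)[nH]c3cncnc32)[C@H](OC(C)=O)[C@@H]1OC(C)=O`: > 122000 nM, a limit of the assay.
Compound 2 `CC(=O)OC[C@H]1O[C@@H](n2c(SCc3cc4ccccc4oc3=O)nc3cncnc32)[C@H](OC(C)=O)[C@@H]1OC(C)=O`: 39000 nM
Compound 3 `CC(=O)OC[C@H]1O[C@@H](n2c(SCc3cc4cc(F)ccc4oc3=O)nc3cncnc32)[C@H](OC(C)=O)[C@@H]1OC(C)=O`: 7600 nM

Only compound 2 and compound 3 have numbers to compare, and compound 3 has the lower one at 7600 nM, so it is the less well tolerated of the pair. The next compound is compound 4 `CC(=O)OC[C@H]1O[C@@H](n2c(SCc3cc4cc(Cl)ccc4oc3=O)nc3cncnc32)[C@H](OC(C)=O)[C@@H]1OC(C)=O`, which differs from compound 3 by chloro in place of fluoro on an aromatic carbon, with chloro in place of fluoro on an aromatic carbon.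

For the measured compounds named here, one measured step bears on this change: a 5.1-fold lower number from compound 2 to compound 3 (0.71 log units; beyond the scatter), for fluoro in place of hydrogen on an aromatic carbon. That step was modest but beyond the scatter. No exchange of one halogen for another has been measured, so its direction offers only weak guidance. Compound 4 is therefore expected to stay close to compound 3 in this assay, with no step beyond the scatter. The expected change is a 1.1-fold lower number from compound 3 to compound 4 (0.04 log units; within the scatter). For compound 4 the estimated value is 7000 nM, within an expected range of 2500 nM to 22000 nM.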

Compound 4, half-maximal cytotoxic concentration: 7500 nM
Compound 4: the middle estimate sits 1.1-fold (0.03 log units) below what was measured; the range from low to high includes it.
By their numbers in this assay, from the lowest: compounds 4 and 3 (each within the scatter of the next); then compound 2. At a limit, above all of these: compound 1.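

In this assay, chloro and fluoro on this aromatic carbon cannot be told apart (a 1.0-fold lower number from compound 3 to compound 4 (0.01 log units; within the scatter)). Chloro in place of hydrogen gives a 5.2-fold lower number from compound 2 to compound 4 (0.72 log units; beyond the scatter), the same direction as fluoro in place of hydrogen (a 5.1-fold lower number from compound 2 to compound 3 (0.71 log units; beyond the scatter)), so among compounds 2, 3 and 4 both halogens go with a lower number than hydrogen, and neither compound 3 nor compound 4 goes against this. Nothing in the data at hand bears on what lies behind this result.

On these data alone, whether the lower number is tied to halogens at all stays open, since a methoxy group or an amine on the same carbon could separate a halogen-specific pattern from one seen with any group replacing hydrogen. As far as these compounds go, whether chloro on another carbon of this ring gives the same reading also stays open.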